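The source may hold more compounds than are shown below. What is called first, only, known or untested is meant among the compounds shown, and "the series" means these compounds.

Compound 1, `O=C(O)COc1cccc(CCCn2cc(C(c3ccccc3)c3ccccc3)ccc2=O)c1`: in an assay on HEK293 cells for displacement of a labelled ligand from chemoattractant receptor-homologous molecule expressed on Th2 cells (Cavia porcellus), read by scintillation counting, with a stated time of 2 h (on this read-out lower numbers stand for stronger inhibition and higher numbers for weaker inhibition), compound 1 gives 256 nM.
Compound 2, `O=C(O)COc1cccc(CCCn2cc(C(c3ccc(Cl)cc3)c3ccc(Cl)cc3)ccc2=O)c1`: compound 2 gives only a limit of the assay, > 1000 nM.
Compound 3, `O=C(O)COc1cccc(CCCN(CCC(c2ccccc2)c2ccccc2)C(=O)c2ccccc2)c1`: compound 3 gives 18 nM.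

Of the two numbers returned by this assay, compound 1 carries the higher one; compound 3 sits well below it, a gap beyond the scatter of repeated measurements. Compound 2 does not supply a number at all: it sits at the limit of > 1000 nM in this assay, at which 1 of the 3 values shown sits, so its separation from compound 1 cannot be sized.

Compound 4, `CC(C)(Oc1cccc(CCCn2cc(C(c3ccccc3)c3ccccc3)ccc2=O)c1)C(=O)O`, keeps the whole core of compound 1 and changes a single place: 1-carboxy-1-methylethyl in place of carboxymethyl on an oxygen on an aromatic ring. No measured pair among the three compounds above isolates this change, so nothing shown here tells how large a step it should bring. Compound 4 is therefore expected to stay near compound 1, with a small step from compound 1 to compound 4 that is estimated as a 1.6-fold higher number from compound 1 to compound 4 (0.19 log units; within the scatter) and that may well fall inside the scatter. On that basis compound 4 is estimated at 400 nM, within a range from 120 nM to 1500 nM.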

Compound 4, half-maximal inhibitory concentration: > 1000 nM
Compound 4: only a limit was reported (the forecaster's own chance of this, stated with the estimate: 15%); middle value at least 2.5-fold (0.39 log units) from the limit.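

In this assay, the first step shown at this position indicates that the read-out is sensitive to the group on an oxygen on an aromatic ring: 1-carboxy-1-methylethyl in place of carboxymethyl brings an at least 3.9-fold higher number from compound 1 to compound 4 (0.59 log units; beyond the scatter). For compound 4 the assay returns only a limit, so this step has a lower bound but no measured size: the limit of > 1000 nM in this assay, at which 2 of the 4 values shown sit. With the rest of the structure unchanged, the carboxymethyl group of compound 1 gives a measurable 256 nM, whereas the larger 1-carboxy-1-methylethyl group gives no number at all.

The compounds shown leave open how a 1-carboxyethyl group, a longer chain such as carboxypropyl, or a primary amide in place of the carboxylic acid would read at this position, and so where along this series the weakening sets in. They also leave open whether the same change would carry over to the different structure of compound 3, which gives 18 nM, as no pair shown tests the change on that structure.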